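The source may hold more compounds than are shown below. What is called first, only, known or untested is meant among the compounds shown, and "the series" means these compounds.

Compounds measured in an assay for positive allosteric modulation of metabotropic glutamate receptor 3 (Rattus norvegicus) (on this read-out lower numbers stand for an effect already at smaller amounts and higher numbers for an effect only at larger amounts of compound), so far:

- compound 1, `Cc1ncc(OCCCCOc2ccc(C(=O)CC(C)(C)C)c(O)c2C)cc1C(=O)O`: 79 nM
- compound 2, `Cc1c(OCCCCOc2cncc(C(=O)O)c2)ccc(C(=O)CC(C)(C)C)c1O`: 180 nM
- compound 3, `COc1cc(OCCCCOc2ccc(C(=O)CC(C)(C)C)c(O)c2C)cc(C(=O)O)c1`: 703 nM

Among these three, compound 2 stands second highest in this assay; it is separated from compound 1 by a step of a 2.3-fold higher number from compound 1 to compound 2 (0.36 log units; beyond the scatter), a change of hydrogen in place of methyl on an aromatic carbon, while compound 3 gives a higher number still.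

Compound 4, `Cc1c(OCCCCOc2ccc(C(=O)O)c(F)c2)ccc(C(=O)CC(C)(C)C)c1O`, has not yet been measured. It differs from compound 2 in that (4-carboxy-3-fluorophenyl in place of 5-carboxypyridin-3-yl on an oxygen on a saturated carbon). Among the measured compounds shown here, no measured step matches this exchange of one carboxylic-acid-bearing aromatic ring for another. For the measured compounds named here, the only measured step, from compound 1 to compound 2, concerns a methyl on a different ring and is modest. Compound 3 shows that a carbon-only aromatic ring with a carboxylic acid and a methoxy group in this position gives a clearly higher number than compound 2, and this is the nearest point of comparison. A moderate rise in the number is therefore expected, with wide uncertainty; the expected step from compound 2 to compound 4 is a 1.9-fold higher number from compound 2 to compound 4 (0.29 log units; within the scatter). Compound 4 is estimated at 350 nM, in a range from 100 nM to 1200 nM.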

Compound 4, half-maximal effective concentration: 1110 nM
Beside the measured number, compound 4's estimate is 3.2-fold (0.50 log units) below it, within the range that was stated.
By their numbers in this assay, from the lowest: compound 1; then compound 2; then compounds 3 and 4 (each within the scatter of the next).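

In this assay the exchange on the oxygen on a saturated carbon gives a 6.2-fold higher number from compound 2 to compound 4 (0.79 log units; beyond the scatter) and, with the added methyl of compound 1 as the starting point, a 14-fold higher number from compound 1 to compound 4 (1.15 log units; beyond the scatter) as the largest step seen so far in this set. Both compounds in the first step carry a carboxylic acid on a six-membered aromatic ring, so having that acid does not by itself hold the number low, and the identity of the ring and its substitution matter here. No measurement offered here explains the rise.

The exchange removes the ring nitrogen, adds a fluorine and changes the ring's substitution at once, so these contributions remain unseparated. From the compounds shown here alone, it remains open how a plain 4-carboxyphenyl group would compare, or a tetrazole in place of the carboxylic acid on the 5-carboxypyridin-3-yl ring.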